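A few compounds are considered here, and "the series" means these few. Any claim that something is new, unique, unknown or untested is made for them only; others in the source may bear on it.

Measured so far:
compound 1 `N=C(S)CCCn1nc(-c2ccccc2)ccc1=O` — 75.6%
compound 2 `Cc1ccc(=O)n(CCCCCC(=N)S)n1` — 36.6%

In a functional assay on the whole organism (stomach) for inhibition, with Rattus norvegicus as the target, at a dose of 100 mg/kg by the intraduodenal route (a lower number here means less inhibition, a higher number more inhibition at the dose given (going by the name of the read-out)), compound 1 gives 75.6% and stands highest of the two numbers in hand. Its nearest neighbour, compound 2, gives 36.6%, a gap that lies beyond the usual scatter of this read-out. Among the compounds with values here, the two measured compounds differ from each other in more than one place, so no step between them can be tied to a single structural change, and nothing of that kind is known yet for the series.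

The next compound, compound 3 `NC(=O)CCn1nc(-c2ccccc2)ccc1=O`, is to be measured in this assay. It differs from compound 1 as follows: a group of 3 heavy atoms (1 carbon, 1 nitrogen, 1 oxygen; no ring) in place of a group of 4 heavy atoms (2 carbon, 1 nitrogen, 1 sulfur; no ring), on a saturated chain carbon, two bonds along the chain from an aromatic nitrogen. Within the data shown here, with no single-change step available, the expectation for compound 3 rests on compound 1 alone and on the size of this change. Some loss of inhibition is expected, beyond the scatter but not to the level of compound 2. For compound 3 the step expected is a number 25.6 percentage points lower from compound 1 to compound 3 (beyond the scatter). Compound 3 is expected to give about 50%, with a range from 20% to 78%.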

Compound 3, a percentage reported as inhibition, in the whole organism at one dose (the size of the read-out at that dose, not a potency): -2.8%
Compound 3: the middle estimate sits 52.8 percentage points above what was measured; the whole stated range lies above it.
By their numbers in this assay, from the lowest: compound 3; then compound 2; then compound 1.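

Within the data shown here, the earlier compounds gave no single-change step, so this is the first reading of how much one place matters. Exchanging the group of 4 heavy atoms (2 carbon, 1 nitrogen, 1 sulfur) for carbamoyl, on a saturated chain carbon, two bonds along the chain from an aromatic nitrogen, gives a number 78.4 percentage points lower from compound 1 to compound 3 (beyond the scatter) in this assay, with the rest of compound 1 unchanged, so the inhibition at this dose depends strongly on the group at this place. The entering group is smaller and carries no sulfur, so this single exchange alters size and atom type together and cannot separate them, and nothing measured here accounts for the loss.

Going by these compounds, it remains open whether the sulfur or the length of the group matters more, which a carbamoyl on a longer chain, with the heavy-atom count of the leaving group restored, would help to settle. On these data alone, it is also open whether a carboxylic acid or an amine at this place would keep any of the inhibition seen with compound 1 in this assay.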